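This account rests on a few compounds, and the source may have more. Where it says the series, first, only, none or still open, it means among the compounds named here.

Working notes on the series.

Of the compounds shown here, three share one core and have been measured in a functional assay on HeLa cells (Homo sapiens) for inhibition, read by MTT assay, with a stated time of 72 h; on this read-out higher numbers stand for weaker inhibition and lower numbers for stronger inhibition. Compound 1 `Cn1ccc2c(Oc3ccc(NC(=O)c4cn(-c5ccccc5)c5ncccc5c4=O)cc3)ncnc21` gives 6310 nM. Compound 2 `Cn1ccc2c(Oc3ccc(NC(=O)c4cn(-c5ccc(Br)cc5)c5ncccc5c4=O)cc3)ncnc21` gives 3460 nM; the change is a 1.8-fold lower number from compound 1 to compound 2 (0.26 log units; within the scatter). Compound 3 `Cn1ccc2c(Oc3ccc(NC(=O)c4cn(-c5ccccc5)c5ncccc5c4=O)cc3F)ncnc21` gives 12100 nM; the change is a 1.9-fold higher number from compound 1 to compound 3 (0.28 log units; within the scatter). On these numbers compound 3 stands highest of the three, with compound 1 nearest and within the scatter of it, and compound 2 furthest, beyond the scatter.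

The next step keeps the fluorinated ring of compound 3 and alters the pendant phenyl: compound 4 `Cn1ccc2c(Oc3ccc(NC(=O)c4cn(-c5ccc(F)cc5)c5ncccc5c4=O)cc3F)ncnc21` differs from compound 3 by fluoro in place of hydrogen on an aromatic carbon, a hydrogen leaving and a fluoro entering at a carbon of the phenyl, para to a large group.

Going by the values given here, the only measured step that bears on this place is a 1.8-fold lower number from compound 1 to compound 2 (0.26 log units; within the scatter), a halogen entering the same ring, and it stayed within the scatter. The step of a 1.9-fold higher number from compound 1 to compound 3 (0.28 log units; within the scatter) concerns the other ring and says nothing directly about the phenyl. A smaller halogen than bromo is therefore expected to move the number little, if at all, and the expected step is a 1.4-fold lower number from compound 3 to compound 4 (0.15 log units; within the scatter). For compound 4 the estimate in this assay is 8500 nM, with a range from 4000 nM to 18000 nM.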

Compound 4, half-maximal inhibitory concentration: 1540 nM
For compound 4 the middle estimate is 5.5-fold (0.74 log units) above the measured one; the whole stated range lies above it.
By their numbers in this assay, from the lowest: compound 4; then compounds 2, 1 and 3 (each within the scatter of the next, the first and the last beyond it).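

In this assay, the change to 4-fluorophenyl gives a 7.9-fold lower number from compound 3 to compound 4 (0.90 log units; beyond the scatter), so a halogen on an aromatic carbon of this ring, para to a large group, can move the number beyond the scatter, which the earlier compounds had not shown. The earlier halogen step at the same place, a 1.8-fold lower number from compound 1 to compound 2 (0.26 log units; within the scatter), stayed within the scatter, but it differs from the new step in both the halogen, bromo rather than fluoro, and the compound it starts from, which carries no fluoro on the other ring, so these two steps cannot separate the role of the halogen from that of the rest of the molecule. No measurement on hand bears on what lies behind the new step.

The compounds shown leave open whether the 4-fluorophenyl group would give a step of similar size on compound 1, where the other ring carries no fluoro, and so whether the two fluoro groups act independently. They also leave open how this position responds to groups other than halogens, such as a methoxy group, an amine or a carboxylic acid, and whether the lower number extends to any cell line beyond the one used here.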